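The source may hold more compounds than are shown below. What is called first, only, known or untested is meant among the compounds shown, and "the series" means these compounds.

Measured so far in a functional assay (trachea) with Rattus norvegicus as the target; on this read-out lower numbers stand for lower potency and higher numbers for higher potency (the scale is a negative logarithm):
compound 1, `CCC(=O)c1ccc2c(c1)C(n1ccccc1=O)=CC(C)(C)O2`: 5.85
compound 2, `CC1(C)C=C(n2ccccc2=O)c2cc(C(=O)c3ccc([N+](=O)[O-])cc3)ccc2O1`: 6.09

Among the compounds with values here, compound 2 holds the higher of the two numbers in this assay, but the single recorded step, a number 0.24 log units higher from compound 1 to compound 2 (within the scatter), lies within the scatter, so the two compounds cannot be ordered against each other.

Compound 3, `CC1(C)C=C(n2ccccc2=O)c2cc(C(=O)c3ccccc3F)ccc2O1`, differs from compound 2 in one place: 2-fluorophenyl in place of 4-nitrophenyl on a carbonyl carbon. Within the data shown here, only one measured step touches the same position, a number 0.24 log units higher from compound 1 to compound 2 (within the scatter), where ethyl gave way to 4-nitrophenyl with no change beyond the scatter. Among the measured compounds shown here, compound 3 keeps an aromatic ring on that carbonyl carbon and exchanges 4-nitrophenyl for 2-fluorophenyl; no measured pair covers an exchange of one such ring for another, nor a ring carrying fluorine. For the measured compounds named here, with the only relevant step flat, the expectation for compound 3 is a step of about a number 0.09 log units lower from compound 2 to compound 3 (within the scatter), that is, nothing beyond the scatter in either direction. Compound 3 is therefore estimated at 6 in this assay, with a range from 5.4 to 6.6.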

Compound 3, logarithm of the reciprocal of the active concentration, log(1/C): 6.34
The estimate for compound 3 lay 0.34 log units below the measured number; measured number inside the range.
By their numbers in this assay, from the lowest: compounds 1, 2 and 3 (each within the scatter of the next, the first and the last beyond it).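

In this assay, the exchange of one aromatic ring for another on the carbonyl carbon gives a number 0.25 log units higher from compound 2 to compound 3 (within the scatter), so 4-nitrophenyl and 2-fluorophenyl cannot be told apart at this position, although one carries a nitro group and the other fluorine. Within the data shown here, the comparison with ethyl gives a number 0.49 log units higher from compound 1 to compound 3 (beyond the scatter), the first step at this position to clear the scatter, though only modestly, and it holds for 2-fluorophenyl alone: compound 2, also an aryl ketone, goes against any general reading of aromatic ring over ethyl, since it lies within the scatter of both neighbours. Nothing available accounts for this step or for the flat exchange between the two rings.

On these data alone, whether the fluorine contributes at all remains open, and plain phenyl on the carbonyl carbon would separate the ring from its substituent. Also open, as far as these compounds go, is how far this position tolerates other kinds of group, such as a longer alkyl chain, a methoxy-substituted phenyl or a piperidine amine, with the rest of the core held constant.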